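Chloro to Methyl on a Weakly Cytotoxic Anilino Analogue

The compounds below may be only part of what the source reports. "The series", "measured", "known", "first", "only" and "open" are said of these compounds alone.

Of the compounds shown here, three have been measured in a functional assay on CCRF-CEM cells (Homo sapiens) for cytotoxicity, read by cell counting, with a stated time of 3 days; a lower number here means a stronger inhibitor, a higher number a weaker inhibitor. Compound 1 `C=C(Br)C(=O)Nc1cccc(/C=C2\SC(=O)N(Cc3ccc(C)cc3)C2=O)c1` gives 1200 nM, and compound 2 `C=C(Br)C(=O)Nc1cccc(/C=C2\SC(=O)N(Cc3ccc(Cl)cc3)C2=O)c1` gives 1400 nM. The two differ only by methyl in place of chloro on an aromatic carbon, and the step of a 1.2-fold lower number from compound 2 to compound 1 (0.07 log units; within the scatter) is therefore treated as no real change.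

Compound 3 `Nc1ccc(/C=C2\SC(=O)N(Cc3ccc(Cl)cc3)C2=O)cc1` belongs to a different core. How the core of compound 3 differs from the core of compound 2 is not broken down here. In this assay compound 3 gives 87000 nM, the highest number of the three and beyond the scatter from both compound 1 and compound 2, so compound 3 is the weakest of the measured set.

Compound 4 `Cc1ccc(CN2C(=O)S/C(=C\c3ccc(N)cc3)C2=O)cc1` has not yet been measured. It differs from compound 3 by methyl in place of chloro on an aromatic carbon, with the place described in the same words as for the pair of compound 2 and compound 1, so this is the same change applied to the second core. For the measured compounds named here, the expected step from compound 3 to compound 4 is a 1.2-fold lower number from compound 3 to compound 4 (0.06 log units; within the scatter), resting on the one earlier instance a 1.2-fold lower number from compound 2 to compound 1 (0.07 log units; within the scatter), which stayed within the scatter. Going by the values given here, with only a single precedent and a different core, the range is kept wide. Compound 4 is expected to give 75000 nM, between 30000 nM and 200000 nM, because compound 3 gives 87000 nM and the change is not expected to move that number meaningfully.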

Compound 4, half-maximal inhibitory concentration: > 250000 nM
Compound 4: a limit, no number; the forecaster's own chance of this, stated with the estimate: 15%; middle value at least 3.3-fold (0.52 log units) from the limit.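

In this assay compound 4 gives > 250000 nM, which is a limit of the assay and not a number: the limit of > 250000 nM in this assay, at which 1 of the 4 values shown sits. Even so, the limit is enough to read the step as an at least 2.8-fold higher number from compound 3 to compound 4 (0.45 log units; beyond the scatter), whereas the same change gave a 1.2-fold lower number from compound 2 to compound 1 (0.07 log units; within the scatter), so methyl in place of chloro on an aromatic carbon did not carry over from one core to the other with the same result: the same change on two cores in this assay, a 1.2-fold lower number (0.07 log units; within the scatter) from compound 2 to compound 1 and an at least 2.8-fold higher number (0.45 log units; beyond the scatter) from compound 3 to compound 4, at least 3.3-fold (0.52 log units) apart, beyond the scatter of two such steps. This does not show how large the step on the second core really is, since only its lower bound can be read, and with a single pair on each core it offers neither a rule for the series nor an explanation of why the two steps differ.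

The compounds shown leave open whether other groups on the same aromatic carbon, such as fluoro, methoxy or hydroxyl, would also give steps that differ between the two cores. Going by these compounds, it also remains open how the 4-chlorophenyl to 4-methylphenyl change would read on a core carrying an acetamide in place of the free amine.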